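This account rests on a few compounds, and the source may have more. Where it says the series, first, only, none or still open, it means among the compounds named here.

Measured compounds:
- Compound 1 `O=C(Nc1nc(-c2cccc(Cl)c2)cs1)c1ccc([N+](=O)[O-])o1` gives 43700 nM in an ADME assay on Vero cells (Chlorocebus sabaeus) for cytotoxicity, read by MTT assay, with a stated time of 72 h; a higher number here means a weaker inhibitor, a lower number a stronger inhibitor.
- Compound 2 `O=C(Nc1nc(-c2c(F)cc(F)cc2F)cs1)c1ccc([N+](=O)[O-])o1` gives 19900 nM in this assay.

Compound 1 stands at the higher of these two numbers; compound 2 lies at a lower one, and the gap between them is beyond the scatter. Compound 3 `O=C(Nc1nc(-c2cccc(NC(=O)C3CCCCC3)c2)cs1)c1ccc([N+](=O)[O-])o1` differs from compound 1 by one change: (cyclohexylcarbonyl)amino in place of chloro on an aromatic carbon. Within the data shown here, no measured pair shows this change, so its effect is unknown. A step from compound 1 to compound 3 of modest size, in either direction or none beyond the scatter, is expected: a 1.5-fold lower number from compound 1 to compound 3 (0.16 log units; within the scatter). Compound 3 is estimated at 30000 nM, within 10000 nM to 80000 nM.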

Compound 3, half-maximal inhibitory concentration: 21900 nM
Compound 3: the middle estimate sits 1.4-fold (0.14 log units) above what was measured; measured number inside the range.
By their numbers in this assay, from the lowest: compounds 2, 3 and 1 (each within the scatter of the next, the first and the last beyond it).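

In this assay, (cyclohexylcarbonyl)amino in place of chloro gives a 2.0-fold lower number from compound 1 to compound 3 (0.30 log units; within the scatter). On this aromatic carbon, then, a single chlorine can give way to a much larger group carrying its own non-aromatic ring, with no step beyond the scatter. Nothing at hand explains this result.

On these data alone, whether a simple amine or a carboxylic acid at this place would also stay within the scatter remains open. As far as these compounds go, it is also open whether the cyclohexyl ring matters, or whether a longer open chain would serve equally well.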